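A few compounds are considered here, and "the series" means these few. Any claim that something is new, unique, unknown or untested is made for them only; others in the source may bear on it.

Measured so far in a functional assay on WRL68 cells (Homo sapiens) for cytotoxicity, read by MTT assay, with stated times of 6 h and 48 h; a lower number here means a stronger inhibitor, a higher number a weaker inhibitor:
- Compound 1 `O=C(/C=C/c1cc(Br)c(Br)[nH]1)c1ccccc1`: >= 100000 nM (a limit, not a number)
- Compound 2 `O=c1cc(-c2cc(Br)c(Br)[nH]2)oc2ccccc12`: >= 100000 nM (a limit, not a number)

Neither compound has yet given a number in this assay. The whole record so far is the limit of >= 100000 nM in this assay, at which 2 of the 2 values shown sit. As far as these compounds go, compound 2 therefore stands at the limit, and how far beyond it compound 2 might lie is unknown.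

The next compound is compound 3 `Cn1c(-c2cc(=O)c3ccccc3o2)cc(Br)c1Br`, which carries methyl in place of hydrogen on an aromatic nitrogen. Going by the values given here, no measured pair shows what this change does in this assay, so the expectation is no step beyond the scatter, in either direction. That expectation rests on compound 2, whose reading of >= 100000 nM is a limit. The estimated step is a number no higher from compound 2 to compound 3 (the limit leaves the size open). A report of only a limit is the likeliest outcome for the next measurement. The expected value for compound 3 is 100000 nM, with an estimated range of 40000 nM to 200000 nM.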

Compound 3, half-maximal inhibitory concentration: >= 100000 nM
Compound 3: a limit, no number; the forecaster's own chance of this, stated with the estimate: 80%; the middle value sits exactly at the limit.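

In this assay compound 3 gives >= 100000 nM, a limit and not a number. Compound 2 also stands only at a limit, so no step can be read between compound 2 and compound 3 for methyl in place of hydrogen on an aromatic nitrogen. The compounds shown leave open how far any of them lies beyond the one reading they share: the limit of >= 100000 nM in this assay, at which 3 of the 3 values shown sit.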